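A few compounds are considered here, and "the series" means these few. Any claim that something is new, unique, unknown or untested is made for them only; others in the source may bear on it.

Measured compounds:
compound 1, `ClCc1ccccc1Cn1cnc2c(Cl)nc(Cl)nc21`, 720 nM
compound 2, `ClCc1ccccc1Cn1cnc2c(Cl)ncnc21`, 3380 nM
compound 3, `ClCc1ccc(Cn2cnc3nc(Cl)nc(Cl)c32)cc1`, 1860 nM

The three compounds were tested in a functional assay on SN12C cells (Homo sapiens) for cytotoxicity, read by sulforhodamine B assay, with a stated time of 48 h; on this read-out higher numbers stand for weaker inhibition of growth and lower numbers for stronger inhibition of growth. Compound 1 gives 720 nM and compound 2 gives 3380 nM, so the change hydrogen in place of chloro on an aromatic carbon produced a 4.7-fold higher number from compound 1 to compound 2 (0.67 log units; beyond the scatter). Compound 3 carries the same atoms as compound 1 joined differently; in this assay compound 3 gives 1860 nM; the difference between the two cores is not broken down here. Compound 4, `ClCc1ccc(Cn2cnc3ncnc(Cl)c32)cc1`, has not yet been tested in this assay. It arises from compound 3 by the change (hydrogen in place of chloro on an aromatic carbon), which is the same change as that from compound 1 to compound 2, at a place described in the same words.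

Among the measured compounds shown here, since the only measured instance of this change, a 4.7-fold higher number from compound 1 to compound 2 (0.67 log units; beyond the scatter), ran clearly beyond the scatter, a step of similar direction is expected from compound 3 to compound 4, estimated as a 4.0-fold higher number from compound 3 to compound 4 (0.61 log units; beyond the scatter). On that basis compound 4 is expected to give about 7500 nM, most likely between 3000 nM and 20000 nM.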

Compound 4, concentration for 50% growth inhibition: 3630 nM
Compound 4: the middle estimate sits 2.1-fold (0.32 log units) above what was measured; measured number inside the range.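

In this assay, hydrogen in place of chloro on the core of compound 3 gave a 2.0-fold higher number from compound 3 to compound 4 (0.29 log units; within the scatter), a step that on its own cannot be read as a real change. Set beside the step on the core of compound 1, it does not differ measurably from it: the same change on two cores in this assay, a 4.7-fold higher number (0.67 log units; beyond the scatter) from compound 1 to compound 2 and a 2.0-fold higher number (0.29 log units; within the scatter) from compound 3 to compound 4, 2.4-fold (0.38 log units) apart, within the scatter of two such steps. This fits the change carrying over from one core to the other, but it does not show that the step has the same size on both cores, and two pairs say nothing about why it is larger or smaller or whether it would hold on any further core.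

The compounds shown leave open how an amine or a methoxy group on that aromatic carbon, in place of chloro or hydrogen, would read in this assay. They also leave open whether a hydroxymethyl group in place of the chloromethyl group would retain any inhibition of growth.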